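Acetyl to 4-methoxybenzyl in a series at the limit

A few compounds are considered here, and "the series" means these few. Any claim that something is new, unique, unknown or untested is made for them only; others in the source may bear on it.

Compound 2 `CC(=O)c1ccc2c(c1)/C(=C/c1cccc(OCc3cn(Cc4ccccc4)nn3)c1)C(=O)N2` is measured in a functional assay on BT-549 cells (Homo sapiens) for inhibition, read by MTT assay, with a stated time of 48 h (a lower number here means a stronger inhibitor, a higher number a weaker inhibitor), only as a limit, where compound 2 gives > 50000 nM. Compound 3 `CC(=O)c1ccc2c(c1)/C(=C\c1cccc(OCc3cn(Cc4ccccc4)nn3)c1)C(=O)N2`, drawn with the other double-bond configuration, likewise reaches only a limit in this assay, at > 50000 nM. The step that the two limits leave unreadable from compound 2 to compound 3 therefore cannot be read from the two limits, the more so because of the fact that compounds 2 and 3 differ only in the configuration as drawn. Compound 1 `O=C1Nc2ccc(Cl)cc2/C1=C/c1cccc(OCc2cn(Cc3ccccc3)nn2)c1` has no result: "not determined" (no result reported). Compound 4 `COc1ccc(Cc2ccc3c(c2)/C(=C/c2cccc(OCc4cn(Cc5ccccc5)nn4)c2)C(=O)N3)cc1` carries 4-methoxybenzyl in place of acetyl on an aromatic carbon. Among the measured compounds shown here, no measured step bears on this change; only the limit of > 50000 nM in this assay, at which 2 of the 3 values shown sit, frames it, so compound 4 is expected to remain near that limit. Compound 4 is estimated at 50000 nM, within 10000 nM to 100000 nM. The expected step of a number no higher from compound 2 to compound 4 (the limit leaves the size open) is thus none beyond the scatter.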

Compound 4, half-maximal inhibitory concentration: 36000 nM
Compound 4: the middle estimate sits 1.4-fold (0.14 log units) above what was measured; measured number inside the range.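

Among the compounds shown, only compound 4 gives a real number in this assay, at 36000 nM, so this aromatic carbon carries 4-methoxybenzyl with a readable result. The step is an at least 1.3-fold lower number from compound 2 to compound 4 (0.14 log units; that floor lies within the scatter), which shows no change beyond the scatter. The true size of that step stays unfixed because compound 2 gives only a limit: the limit of > 50000 nM in this assay, at which 2 of the 4 values shown sit.

Going by these compounds, whether the other double-bond configuration of compound 4 gives a similar number remains open. So does whether an amine or a carboxylic acid at this position gives a lower number.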